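Chloro to Methyl, in Two Places of a Shared Core

The source may report more compounds than this note shows. Statements on the series, on what has been measured and on what is new or still open speak of the compounds shown alone.

Compound 1 `N#Cc1c(Nc2cccc(Cl)c2)nc(SCc2cn(Cc3ccccc3Cl)nn2)nc1-c1ccccc1` and compound 2 `Cc1cccc(Nc2nc(SCc3cn(Cc4ccccc4Cl)nn3)nc(-c3ccccc3)c2C#N)c1` differ in one spot only. In a functional assay on MGC-803 cells (Homo sapiens) for inhibition, read by MTT assay, with a stated time of 72 h (on this read-out lower numbers stand for stronger inhibition and higher numbers for weaker inhibition), compound 1 gives 15800 nM, and compound 2 gives 16200 nM. The change between them is methyl in place of chloro on an aromatic carbon, and the step it made was a 1.0-fold higher number from compound 1 to compound 2 (0.01 log units; within the scatter). Compound 3 `N#Cc1c(Nc2ccccc2F)nc(SCc2cn(Cc3ccc(Cl)cc3)nn2)nc1-c1ccccc1` is built differently, and the difference between its core and the core of compound 1 is not broken down here. In this assay compound 3 reports only a limit, > 64000 nM, which is the limit of > 64000 nM in this assay, at which 1 of the 3 values shown sits. Compound 4 `Cc1ccc(Cn2cc(CSc3nc(Nc4ccccc4F)c(C#N)c(-c4ccccc4)n3)nn2)cc1` has not been measured yet; it differs from compound 3 by methyl in place of chloro on an aromatic carbon. Among the compounds with values here, this is the same kind of change as the one between compound 1 and compound 2, but not the same: in compound 1 the group sits meta to a large group, whereas in compound 3 it sits para to a large group, on a different ring. Because the earlier step of a 1.0-fold higher number from compound 1 to compound 2 (0.01 log units; within the scatter) lay within the scatter, the expected step is a step that the limit leaves unreadable from compound 3 to compound 4. Compound 4 is therefore estimated at 70000 nM, and this assay may well report only a limit again.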

Compound 4, half-maximal inhibitory concentration: 22900 nM
For compound 4 the middle estimate is 3.1-fold (0.49 log units) above the measured one; measured number below the stated range.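

Compound 3 stands only at a limit of the assay, > 64000 nM. In this assay, 4-chlorobenzyl to 4-methylbenzyl gives an at least 2.7-fold lower number from compound 3 to compound 4 (0.44 log units; beyond the scatter), so methyl in place of chloro did not behave the same way in the two pairs, and the result from the first pair could not simply be carried over to the second: the same change on two cores in this assay, a 1.0-fold higher number (0.01 log units; within the scatter) from compound 1 to compound 2 and an at least 2.7-fold lower number (0.44 log units; beyond the scatter) from compound 3 to compound 4, at least 2.8-fold (0.45 log units) apart, beyond the scatter of two such steps

The two pairs do not show why the steps differ: the change sits on a different ring in each pair and the rest of the structure differs too, so the role of the ring cannot be separated from that of the surrounding core, and the full size of the new step remains unknown.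

On these data alone, it remains open whether a methoxy group or an amine in place of the methyl would give a similar number on the core of compound 4. As far as these compounds go, it also remains open whether methyl in place of chloro on the benzyl ring of compound 1 would produce a step like the new one.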